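Moving from benzyl to 2-sulfoethyl on the shared core

The compounds below may be only part of what the source reports. "The series", "measured", "known", "first", "only" and "open" are said of these compounds alone.

- compound 1 `CCCn1c(=N)sc2cc(OC(F)(F)F)ccc21` gives 4.5 mg/kg
- compound 2 `C#CCn1c(=N)sc2cc(OC(F)(F)F)ccc21` gives 4 mg/kg
- compound 3 `N=c1sc2cc(OC(F)(F)F)ccc2n1Cc1ccccc1` gives > 10 mg/kg (a limit)
- compound 4 `N=c1sc2cc(OC(F)(F)F)ccc2n1CCS(=O)(=O)O` is not yet measured

In a functional assay on the whole organism with Rattus norvegicus as the target (a higher number here means that more compound is needed for the effect, a lower number that less compound is needed), compound 3 stands at > 10 mg/kg, which is a limit and not a number. Compound 4 differs from it by sulfomethyl in place of phenyl on a saturated chain carbon bound to an aromatic nitrogen, in words sulfomethyl in place of phenyl on a saturated chain carbon bound to an aromatic nitrogen. Three measured steps fall at this place. The step of a 1.1-fold lower number from compound 1 to compound 2 (0.05 log units; within the scatter) is small. The steps of an at least 2.2-fold higher number from compound 1 to compound 3 (0.34 log units; beyond the scatter) and an at least 2.5-fold higher number from compound 2 to compound 3 (0.39 log units; beyond the scatter) both bring in the phenyl that now leaves, so a modest fall in the number is expected, although sulfomethyl appears in none of them. The expected step is an at least 1.2-fold lower number from compound 3 to compound 4 (0.09 log units; that floor lies within the scatter). For compound 4 the estimated value is 8 mg/kg, with an expected range from 3 mg/kg to 25 mg/kg.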

Compound 4, dose for half-maximal effect: > 10 mg/kg
Compound 4 gave a limit, no number (the forecaster's own chance of this, stated with the estimate: 40%); middle value at least 1.2-fold (0.09 log units) from the limit.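

In this assay, the 2-sulfoethyl group brings an at least 2.2-fold higher number from compound 1 to compound 4 (0.34 log units; beyond the scatter) and an at least 2.5-fold higher number from compound 2 to compound 4 (0.39 log units; beyond the scatter). This group holds no ring, so a rise in the number at this position does not require the ring of the benzyl group in compound 3. The step between compound 3 and compound 4 cannot be read, because both values are limits and not numbers: the limit of > 10 mg/kg in this assay, at which 2 of the 4 values shown sit.

On these data alone, the true doses needed for compound 3 and compound 4 stay open. So does whether a carboxylic acid or an amine at the end of the chain would behave like the sulfo group.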